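Trifluoromethoxy for Fluoro on Two Related Cores

The source may report more compounds than this note shows. Statements on the series, on what has been measured and on what is new or still open speak of the compounds shown alone.

Compound 2 `Cc1ccc2c(=O)[nH]c(-c3ccccc3F)nc2c1` and compound 3 `Cc1ccc2nc(-c3ccccc3F)[nH]c(=O)c2c1` are built from the same atoms joined differently; the difference between the two cores is not broken down here. In a functional assay on HeLa cells (Homo sapiens) for cytotoxicity, read by MTT assay, with a stated time of 2 days (a higher number here means a weaker inhibitor, a lower number a stronger inhibitor), compound 2 gives 830 nM. For compound 3 the result in this assay is only a limit of the assay, > 50000 nM, the same limit noted as the limit of > 50000 nM in this assay, at which 1 of the 3 values shown sits. Compound 1 `Cc1ccc2c(=O)[nH]c(-c3ccccc3OC(F)(F)F)nc2c1` arises from compound 2 through one change, (trifluoromethoxy in place of fluoro on an aromatic carbon), and in this assay compound 1 gives 18300 nM, which amounts to a 22-fold higher number from compound 2 to compound 1 (1.34 log units; beyond the scatter). Compound 4 `Cc1ccc2nc(-c3ccccc3OC(F)(F)F)[nH]c(=O)c2c1` has not been measured in this assay; it arises from compound 3 through the same kind of change, (trifluoromethoxy in place of fluoro on an aromatic carbon). Compound 3 already reports only a limit, so no numerical step can be read off for it. Because the measured pair showed a 22-fold higher number from compound 2 to compound 1 (1.34 log units; beyond the scatter), the writer expects compound 4 to be no stronger than compound 3 in this assay, with an expected step that the limit leaves unreadable from compound 3 to compound 4. The estimate for compound 4 in this assay is 200000 nM, between 50000 nM and 1000000 nM, most likely reported only as a limit.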

Compound 4, half-maximal inhibitory concentration: 850 nM
Compound 4: the middle estimate sits 240-fold (2.37 log units) above what was measured; measured number outside the range, below it.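

In this assay, trifluoromethoxy in place of fluoro on an aromatic carbon gives an at least 58-fold lower number from compound 3 to compound 4 (1.76 log units; beyond the scatter), and the same change on one core did not foretell its result on the other: the same change on two cores in this assay, a 22-fold higher number (1.34 log units; beyond the scatter) from compound 2 to compound 1 and an at least 58-fold lower number (1.76 log units; beyond the scatter) from compound 3 to compound 4, at least 1200-fold (3.11 log units) apart, beyond the scatter of two such steps

Compound 3 gives > 50000 nM, which is a limit of the assay.

With one pair on each core, this shows that the direction of the step differs between the two cores for these four compounds, but it does not show why, and it sets no rule for any other core or any other replacement.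

The compounds shown leave open how other groups on the same aromatic carbon, such as a methoxy group or an amine, would behave on each of the two cores. They also leave open whether the two cores would part in the same way if the methyl group gave way to a longer chain or a carboxylic acid.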